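Compound 4: methylcarbamoyl in place of methyl

The source may report more compounds than this note shows. Statements on the series, on what has been measured and on what is new or still open speak of the compounds shown alone.

In a functional assay on NCI-H1975 cells (Homo sapiens) for antiproliferative activity, with a stated time of 72 h (a higher number here means a weaker inhibitor of growth, a lower number a stronger inhibitor of growth), compound 2 (`Cc1ccc(CN(C)C(=O)c2cc(Cl)c(O)cc2O)cc1`) gives 34300 nM, the second highest of three numbers. Compound 1 (`CCNC(=O)c1ccc(CN(C)C(=O)c2cc(Cl)c(O)cc2O)cc1`) gives 21700 nM and compound 3 (`Cc1ccccc1CN(C)C(=O)c1cc(Cl)c(O)cc1O`) gives 47500 nM, each within the scatter of compound 2.

Compound 4 (`CNC(=O)c1ccc(CN(C)C(=O)c2cc(Cl)c(O)cc2O)cc1`) carries methylcarbamoyl in place of methyl on an aromatic carbon, para to a large group: methylcarbamoyl in place of methyl on an aromatic carbon.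

The closest measured change is a 1.6-fold higher number from compound 1 to compound 2 (0.20 log units; within the scatter), which runs the opposite way, with methyl in place of ethylcarbamoyl. The other measured step, a 1.4-fold higher number from compound 2 to compound 3 (0.14 log units; within the scatter), has 2-methylphenyl in place of 4-methylphenyl and bears on this change only indirectly. No measurement separates methylcarbamoyl from ethylcarbamoyl. Read in reverse, a 1.6-fold higher number from compound 1 to compound 2 (0.20 log units; within the scatter) suggests no change beyond the scatter, and at most a slight move toward a lower number in this assay.

The expected step is a 1.4-fold lower number from compound 2 to compound 4 (0.14 log units; within the scatter). For compound 4 the estimated value is 25000 nM, with an expected range of 13000 nM to 45000 nM.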

Compound 4, concentration for 50% growth inhibition: 34800 nM
Compound 4: the middle estimate sits 1.4-fold (0.14 log units) below what was measured; measured number inside the range.
By their numbers in this assay, from the lowest: compounds 1, 2, 4 and 3 (each within the scatter of the next, the first and the last beyond it).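

In this assay the direct swap on the aromatic carbon, para to a large group, gives a 1.0-fold higher number from compound 2 to compound 4 (0.01 log units; within the scatter), so methylcarbamoyl, with its added hydrogen-bond donor and acceptor, does not separate from methyl. The two carbamoyl groups can now also be compared, with hydrogen in place of methyl on the saturated chain carbon bound to the amide-type nitrogen giving a 1.6-fold higher number from compound 1 to compound 4 (0.21 log units; within the scatter), and this step too stays within the scatter. No supporting data bear on why these three groups give such similar numbers.

From the compounds shown here alone, whether a carboxylic acid, a primary amine or a longer chain such as propylcarbamoyl at this position would give a step beyond the scatter remains open. So does the effect of dimethylcarbamoyl, which has no amide hydrogen.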